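The source may hold more compounds than are shown below. What is called first, only, known or untested is meant among the compounds shown, and "the series" means these compounds.

Measured so far in a functional assay on K562 cells (Homo sapiens) for inhibition; on this read-out higher numbers stand for weaker inhibition and lower numbers for stronger inhibition:
compound 1 `CCCCCC/C=C/c1cc(C)oc(=O)c1`: > 50000 nM
compound 2 `CCCCc1cc(C)oc(=O)c1`: > 50000 nM
compound 3 `Cc1cc(C#Cc2ccccc2)cc(=O)o1`: 4000 nM

The value of compound 2 in this assay is a limit of the assay, not a number. Within the data shown here, the value of compound 1 is a limit as well. the limit of > 50000 nM in this assay, at which 2 of the 3 values shown sit. Compound 3 is the one compound with a number. Compound 4 `CCc1cc(C)oc(=O)c1` differs from compound 2 as follows: hydrogen in place of ethyl on a saturated chain carbon, two bonds along the chain from an aromatic carbon. Among the measured compounds shown here, no step between measured compounds is available to size this change. Compound 2 sits at the limit of this assay. The expected step that the limit leaves unreadable from compound 2 to compound 4 is none beyond the scatter. Compound 4 is therefore estimated at 70000 nM, with a range from 20000 nM to 300000 nM, and is expected most likely to be reported again only as a limit.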

Compound 4, half-maximal inhibitory concentration: > 50000 nM
Compound 4 ended at the assay's limit; the forecaster's own chance of this, stated with the estimate: 80%; the middle value lies beyond the limit too.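

Compound 2 and compound 4 both stand at a limit of this assay and not at a number, and no new step can be read between them. The compounds shown leave open what size, if any, the change from butyl to ethyl has on inhibition.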